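A Methoxy Added to the Benzyl Amide

A few compounds are considered here, and "the series" means these few. Any claim that something is new, unique, unknown or untested is made for them only; others in the source may bear on it.

Measured in a functional assay on cells (Homo sapiens) for cytotoxicity, read by MTT assay, with a stated time of 48 h; on this read-out higher numbers stand for weaker inhibition and lower numbers for stronger inhibition:
compound 1 `CN(C)CCCCN(C)C1=Nc2ccccc2C(CC(=O)NCc2ccccc2)N1c1ccc(-c2ccccc2)cc1`, 3970 nM
compound 2 `CN(C)CCCCCCN(C)C1=Nc2ccccc2C(CC(=O)NCc2ccccc2)N1c1ccc(-c2ccccc2)cc1`, 1740 nM
compound 3 `CN(C)CCN1CCN(C2=Nc3ccccc3C(CC(=O)NCc3ccccc3)N2c2ccc(-c3ccccc3)cc2)CC1`, 2390 nM

Compound 3 stands second highest of the three numbers. Its nearest neighbour is compound 2, with a 1.4-fold higher number from compound 2 to compound 3 (0.14 log units; within the scatter), and its furthest is compound 1, with a 1.7-fold lower number from compound 1 to compound 3 (0.22 log units; within the scatter); both gaps lie within the scatter. For the measured compounds named here, the only step beyond the scatter is a 2.3-fold lower number from compound 1 to compound 2 (0.36 log units; beyond the scatter), a modest one, and it concerns the dimethylamino-containing chain, as do the other two steps.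

Compound 4 `COc1ccc(CNC(=O)CC2c3ccccc3N=C(N3CCN(CCN(C)C)CC3)N2c2ccc(-c3ccccc3)cc2)cc1` differs from compound 3 by methoxy in place of hydrogen on an aromatic carbon. Going by the values given here, this change sits on the benzyl amide part of the shared core, which no measured step has varied: every one of the three measured compounds carries the same unsubstituted benzyl group. Among the compounds with values here, none of the measured steps therefore bears on this change, and the data give no ground to expect a shift in either direction beyond the scatter in this assay.

Compound 4 is accordingly expected to give about 2400 nM in this assay, with a range of 1000 nM to 5800 nM. The expected step from compound 3 to compound 4 is a 1.0-fold higher number from compound 3 to compound 4 (0.00 log units; within the scatter), that is, no change beyond the scatter.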

Compound 4, half-maximal inhibitory concentration: 3820 nM
Estimate against measurement, compound 4: 1.6-fold (0.20 log units) below; measured number inside the range.
By their numbers in this assay, from the lowest: compounds 2, 3, 4 and 1 (each within the scatter of the next, the first and the last beyond it).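

In this assay, for the compounds shown here, the benzyl amide part of the shared core varies for the first time, and the change from benzyl to 4-methoxybenzyl gives a 1.6-fold higher number from compound 3 to compound 4 (0.20 log units; within the scatter) within one sentence of reading. Going by these compounds alone, this shows that a single methoxy on this aromatic carbon, para to a large group, yields a number that cannot be told apart from that of the unsubstituted benzyl, so the earlier finding that the chain can vary within a narrow spread of numbers now has a first counterpart on the amide side, limited to this one pair. Nothing available explains this result or says what the methoxy does in the cells.

The compounds shown leave open whether a larger or different group at this place, such as a chlorine atom, a hydroxy group or an amine, or a methoxy on another carbon of the same ring, would give a step beyond the scatter. Within the data shown here, they also leave open whether the methoxy would read the same alongside the open dimethylamino chains of compound 1 and compound 2, since its only comparison here is with the piperazine-bearing compound 3.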